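Primary sulfamoyl analogue in the methylpyrazolyl series

A few compounds are considered here, and "the series" means these few. Any claim that something is new, unique, unknown or untested is made for them only; others in the source may bear on it.

Measured so far:
compound 1, `CCCNS(=O)(=O)c1ccc(Nc2ncc3c(n2)N(C2CCCC2)[C@H](CC)C(=O)N3C)cc1`: 278 nM
compound 2, `CCC1C(=O)N(C)c2cnc(Nc3ccc(S(=O)(=O)NCC(C)C)cc3)nc2N1c1ccn(C)n1`: 8520 nM

Of the compounds shown here, two have been measured in a functional assay on Huh-7 cells (Homo sapiens) for antiproliferative activity, read by CCK-8 assay, with a stated time of 72 h; on this read-out lower numbers stand for stronger inhibition of growth and higher numbers for weaker inhibition of growth. Compound 1 gives 278 nM in this assay, while compound 2 gives 8520 nM, the higher of the two numbers. The two structures differ in more than one place, so the gap between them cannot be assigned to a single change; it only shows that compound 2 is the weaker of the pair in this assay, and by a margin that the two values put well beyond the scatter.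

The next compound, compound 3, `CCC1C(=O)N(C)c2cnc(Nc3ccc(S(N)(=O)=O)cc3)nc2N1c1ccn(C)n1`, keeps the core and the methylpyrazolyl group of compound 2 and alters only the sulfonamide end: hydrogen in place of isobutyl on a sulfonamide nitrogen.

Among the compounds with values here, no measured pair shows what this particular change does in this assay, so the expected step is uncertain. The working expectation is a small step for compound 3, a 1.4-fold lower number from compound 2 to compound 3 (0.15 log units; within the scatter), leaning toward a lower number but not clearly beyond the scatter. On that basis compound 3 is estimated at 6000 nM in this assay, with a range from 2000 nM to 20000 nM.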

Compound 3, concentration for 50% growth inhibition: "not active" (no number reported)
Compound 3 has no reported number here; there is nothing to compare the estimate with.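

Within the data shown here, compound 3 has no reported number in this assay, so no step from compound 2 to compound 3 can be read, and no supporting data bear on this result.

The compounds shown leave open how far replacing isobutyl with hydrogen on the sulfonamide nitrogen shifts growth inhibition in this assay.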